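The source may report more compounds than this note shows. Statements on the series, on what has been measured and on what is new or still open speak of the compounds shown alone.

Measured compounds:
compound 1 `NS(=O)(=O)c1ccc(N2N=C(c3ccc(F)cc3)CC2c2cn(-c3ccccc3)nc2-c2ccccc2)cc1` — in a functional assay on the whole organism (strain Wistar albino) for inhibition, with Rattus norvegicus as the target, read by paw edema, with stated times of 30 min and 120 min, at a dose of 50 mg/kg by the oral route (on this read-out lower numbers stand for less inhibition and higher numbers for more inhibition at the one dose given (going by the name of the read-out)), compound 1 gives 15%
compound 2 `Cc1ccc(-c2nn(-c3ccccc3)cc2C2CC(c3ccccc3)=NN2c2ccc(S(N)(=O)=O)cc2)cc1` — in this assay compound 2 gives 16%

Compound 2 stands alongside compound 1: the two numbers differ by an amount that lies within the usual scatter of this kind of measurement, so no order between them can be read, and neither number can be called the higher or the lower. Going by the values given here, only two compounds have numbers, and no single-point change between them has been measured, so there is no measured step to lean on.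

The next compound, compound 3 `Cc1ccc(C2=NN(c3ccc(S(N)(=O)=O)cc3)C(c3cn(-c4ccccc4)nc3-c3ccc(C)cc3)C2)cc1`, is compound 2 with one change: methyl in place of hydrogen on an aromatic carbon. Among the compounds with values here, with no measured step, the expectation for this assay is a step of no size beyond the scatter, in no particular direction. Compound 3 is therefore estimated to give about 17%, from 8% to 28%, which means an expected step of a number 1 percentage points higher from compound 2 to compound 3 (within the scatter).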

Compound 3, a percentage reported as inhibition, in the whole organism at one dose (the size of the read-out at that dose, not a potency): 9%
Compound 3: the middle estimate sits 8 percentage points above what was measured; measured number inside the range.
By their numbers in this assay, from the lowest: compounds 3, 1 and 2 (each within the scatter of the next).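

Going by these compounds alone, replacing phenyl with 4-methylphenyl gives the first measured single-place step: in this assay, a number 7 percentage points lower from compound 2 to compound 3 (within the scatter). This step lies within the scatter, so adding methyl on this aromatic carbon, para to a large group, has no readable effect on the read-out. Within the data shown here, with only this one step, the result applies to this pair alone and sets no trend for the position. No available evidence bears on a cause for this result.

On these data alone, whether an amine, a carboxylic acid or a methoxy group at the same carbon would give a step beyond the scatter remains open. Also open, as far as these compounds go, is whether methyl at this position would behave the same way with other groups elsewhere on the shared core.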